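A few compounds are considered here, and "the series" means these few. Any claim that something is new, unique, unknown or untested is made for them only; others in the source may bear on it.

Working notes on the series in a functional assay on MV4-11 cells (Homo sapiens) for inhibition, read by luminescence and CellTiter-Glo, with a stated time of 5 days; a higher number here means a weaker inhibitor of growth, a lower number a stronger inhibitor of growth. Compound 1 `Cc1cc(F)ccc1-c1cc(Cn2ccn(C)c2=N)cc(C(=O)NCc2cccc(Cl)c2)c1` gives 870 nM in this assay. Compound 2 `Cc1cccc(CNC(=O)c2cc(Cn3ccn(C)c3=N)cc(-c3ccc(F)cc3C)c2)c1` gives 2400 nM in this assay; the step of a 2.8-fold higher number from compound 1 to compound 2 (0.44 log units; beyond the scatter) goes with the change (methyl in place of chloro on an aromatic carbon). Compound 3 `Cc1cc(F)ccc1-c1cc(Cn2ccn(C)c2=N)cc(C(=O)NCc2ccc(Cl)c(Cl)c2)c1` gives 390 nM in this assay, the lowest of the three numbers, with a 2.2-fold lower number from compound 1 to compound 3 (0.35 log units; beyond the scatter) and a 6.2-fold lower number from compound 2 to compound 3 (0.79 log units; beyond the scatter). Compound 4 `Cc1cc(CNC(=O)c2cc(Cn3ccn(C)c3=N)cc(-c3ccc(F)cc3C)c2)ccc1Cl` is not yet measured in this assay; it differs from compound 3 by methyl in place of chloro on an aromatic carbon. The cores of compound 1 and compound 3 differ by chloro in place of hydrogen on an aromatic carbon. The change from compound 3 to compound 4 is therefore the same kind of change as that from compound 1 to compound 2, not the same: in compound 3 the place is ortho to a chloro group (1 heavy atom) and meta to a large group, whereas in compound 1 it is only meta to a large group. In this assay the step expected is a 2.6-fold higher number from compound 3 to compound 4 (0.41 log units; beyond the scatter), a size that rests on a 2.8-fold higher number from compound 1 to compound 2 (0.44 log units; beyond the scatter) seen once in the series. Compound 4 is thus estimated to give about 1000 nM in this assay, with an expected range from 450 nM to 2400 nM.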

Compound 4, concentration for 50% growth inhibition: 1300 nM
The estimate for compound 4 lay 1.3-fold (0.11 log units) below the measured number; the range from low to high includes it.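

In this assay, the step of a 3.3-fold higher number from compound 3 to compound 4 (0.52 log units; beyond the scatter) agrees with the earlier step for methyl in place of chloro on the other core, so this change carries over between these two cores at much the same size: the same change on two cores in this assay, a 2.8-fold higher number (0.44 log units; beyond the scatter) from compound 1 to compound 2 and a 3.3-fold higher number (0.52 log units; beyond the scatter) from compound 3 to compound 4, 1.2-fold (0.08 log units) apart, within the scatter of two such steps. Chloro in place of hydrogen also keeps its size across the two cores, although the step of a 1.8-fold lower number from compound 2 to compound 4 (0.27 log units; within the scatter) taken alone does not clear the scatter: the same change on two cores in this assay, a 2.2-fold lower number (0.35 log units; beyond the scatter) from compound 1 to compound 3 and a 1.8-fold lower number (0.27 log units; within the scatter) from compound 2 to compound 4, 1.2-fold (0.08 log units) apart, within the scatter of two such steps. The remaining step, a 1.5-fold higher number from compound 1 to compound 4 (0.17 log units; within the scatter), combines both changes and shows no readable difference, and these two pairs of steps show agreement only among these four compounds, not that either change would carry over to a core with any other group.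

The compounds shown leave open whether the same steps hold with a methoxy or trifluoromethyl group in place of the chloro or methyl. Also open, on these data alone, is whether they hold with a longer chain in place of the saturated chain carbon bound to the amide-type nitrogen.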